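The source may report more compounds than this note shows. Statements on the series, on what has been measured and on what is new or still open speak of the compounds shown alone.

Measured in a functional assay on SW-620 cells (Homo sapiens) for cytotoxicity; on this read-out lower numbers stand for stronger inhibition of growth and higher numbers for weaker inhibition of growth:
- Compound 1 `COc1ccc(C2=C(c3ccc(SC)cc3)CC3CCCN3C2=O)cc1Br`: 5000 nM
- Compound 2 `COc1ccc(C2=C(c3ccc(SC)cc3)CC3CCCN3C2=O)cc1C`: 500 nM

Compound 2 holds the lower of the two numbers in this assay, at 500 nM. The next compound, not yet measured, is compound 3 `CSc1ccc(C2=C(c3ccc(Br)cc3)C(=O)N3CCCC3C2)cc1`. The change is 4-bromophenyl in place of 4-methoxy-3-methylphenyl on a double-bonded ring carbon.

Among the measured compounds shown here, only one measured step bears on this: a 10-fold lower number from compound 1 to compound 2 (1.00 log units; beyond the scatter), with methyl in place of bromo on an aromatic carbon. That step is modest but beyond the scatter. It is only an indirect guide, as it covers a single group on the aromatic ring, whereas here the whole aryl group is exchanged. For the measured compounds named here, no measured compound shows the effect of removing the methoxy. Read in reverse, the step points toward a higher number for a bromo-bearing ring, and a somewhat smaller shift is expected here. The expected step is a 6.0-fold higher number from compound 2 to compound 3 (0.78 log units; beyond the scatter). For compound 3 the estimated value is 3000 nM, with an expected range of 800 nM to 10000 nM.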

Compound 3, concentration for 50% growth inhibition: 7000 nM
The estimate for compound 3 lay 2.3-fold (0.37 log units) below the measured number; low and high end bracket the measured number.
By their numbers in this assay, from the lowest: compound 2; then compounds 1 and 3 (each within the scatter of the next).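

In this assay, among the compounds shown here, the full exchange of the aryl group on the double-bonded ring carbon gives a 14-fold higher number from compound 2 to compound 3 (1.15 log units; beyond the scatter) as 4-bromophenyl replaces 4-methoxy-3-methylphenyl, a large step that shows this position responds to more than the single methyl-for-bromo change seen earlier. The 3-bromo-4-methoxyphenyl and 4-bromophenyl groups are not separated, with a 1.4-fold higher number from compound 1 to compound 3 (0.15 log units; within the scatter) in this read-out, so among the three compounds, both bromo-bearing aryl groups stand apart from 4-methoxy-3-methylphenyl, and the methoxy shows no effect of its own when bromine is present on the ring. No supporting data are available to explain these differences.

Since the methoxy and the methyl leave together in the step to compound 3, the compounds shown do not settle how much each contributes when no bromine is present, or whether the methyl alone would hold the lower number. Also open, going by these compounds, is how this position would read with a longer chain such as ethyl in place of the methyl, or with an amine or a carboxylic acid on the aryl ring.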